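Removing one methyl from a bivalent histamine H2 agonist

This account rests on a few compounds, and the source may have more. Where it says the series, first, only, none or still open, it means among the compounds named here.

Two compounds carry the same shared core, a long chain linking two acylguanidine ends, each capped by an aminothiazole. Compound 1 `Cc1nc(N)sc1CCCN/C(N)=N/C(=O)CCCCCCCCC(=O)/N=C(\N)NCCCc1sc(N)nc1C` and compound 2 `Cc1nc(N)sc1CCCN/C(N)=N/C(=O)CCCCCCCCCCC(=O)/N=C(\N)NCCCc1sc(N)nc1C` differ only in chain length. In an in vitro functional assay on Sf9 cells for agonist activity at histamine H2 receptor (Homo sapiens) (a lower number here means that less compound is needed, a higher number that more compound is needed for the effect), compound 1 gives 7.76 nM, the lower of the two numbers, and compound 2 gives 16.6 nM, a gap beyond the scatter.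

Compound 3 `Cc1nc(N)sc1CCCN/C(N)=N/C(=O)CCCCCCCCC(=O)/N=C(\N)NCCCc1cnc(N)s1` keeps the shorter chain of compound 1 and changes one end: hydrogen in place of methyl on an aromatic carbon, so one of the two caps becomes 2-amino-1,3-thiazol-5-yl. Among the measured compounds shown here, no measured pair shows this change, so its size is not known from the data. The expectation is a moderate loss, a step of a 3.2-fold higher number from compound 1 to compound 3 (0.51 log units; beyond the scatter) toward a higher number. Compound 3 is estimated at 25 nM in this assay, with a range from 8 nM to 80 nM.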

Compound 3, half-maximal effective concentration: 13.8 nM
Compound 3: middle estimate off by 1.8-fold (0.26 log units), on the high side; the measured number falls inside the stated range.
By their numbers in this assay, from the lowest: compounds 1, 3 and 2 (each within the scatter of the next, the first and the last beyond it).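

In this assay, the step of a 1.8-fold higher number from compound 1 to compound 3 (0.25 log units; within the scatter) lies within the usual scatter, so replacing this methyl with hydrogen on one cap gives no difference that these numbers can resolve. Among the compounds shown here, the earlier pair differed only in chain length and said nothing about the caps, so this is the first reading at this position, and one methyl on this aromatic carbon does not appear to be needed for a value in this range. Nothing available here gives a reason for this result.

Still open, from the compounds shown here alone, is what a larger group on this carbon, such as an ethyl or a chlorine, would do, and whether removing the methyl from both caps would give a clear step. It is also unknown whether the same replacement on the longer chain of compound 2 would stay equally small.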